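Two Small Changes on a Shared Core: Expecting Compound 4

The compounds below may be only part of what the source reports. "The series", "measured", "known", "first", "only" and "open" are said of these compounds alone.

Measured so far, in an assay on membranes from HEK293 cells for displacement of a labelled ligand from adenosine receptor A2b (Homo sapiens), read by scintillation counting, with a stated time of 30 min, tested at 1 uM; a lower number here means less inhibition, a higher number more inhibition at the concentration tested (going by the name of the read-out):
Compound 1 `CC1=C(C(=O)OCC(C)C)C(c2ccco2)NC(=O)N1C` gives 4%.
Compound 2 `CC1=C(C(=O)OC(C)(C)C)C(c2ccco2)NC(=O)N1C` gives 26%.
Compound 3 `CC1=C(C(=O)OCC(C)C)C(c2cccs2)NC(=O)N1C` gives 2%.

Of the compounds shown here, three have been measured, and they differ from one another in only one place at a time. Between compound 1 and compound 2 the change is tert-butyl in place of isobutyl on an oxygen next to a carbonyl group, and it made a step of a number 22 percentage points higher from compound 1 to compound 2 (beyond the scatter). Between compound 1 and compound 3 the change is thiophen-2-yl in place of furan-2-yl on a saturated ring carbon, and the step was a number 2 percentage points lower from compound 1 to compound 3 (within the scatter), so compound 1 and compound 3 cannot be told apart in this assay. Compound 2 and compound 3 have no single-step relation shown here; their two values simply show compound 2 clearly the higher of the pair.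

Compound 4 `CC1=C(C(=O)OC(C)(C)C)C(c2cccs2)NC(=O)N1C` has not been measured. It differs from compound 3 by tert-butyl in place of isobutyl on an oxygen next to a carbonyl group. Among the measured compounds shown here, this is the same change as the one from compound 1 to compound 2, made on a core that differs as described by the difference between compound 1 and compound 3. Since the change sits at the same place in both pairs, the expectation is that it behaves the same way: the estimated step is a number 18 percentage points higher from compound 3 to compound 4 (beyond the scatter), resting on the earlier step of a number 22 percentage points higher from compound 1 to compound 2 (beyond the scatter) and on the start point of compound 3 at 2%. For the measured compounds named here, only one prior example of the change exists, so the range is kept wide. Compound 4 is expected to give about 20%, somewhere between 4% and 40%.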

Compound 4, a percentage reported as inhibition, at one concentration (the size of the read-out at that concentration, not a potency): 24%
Beside the measured number, compound 4's estimate is 4 percentage points below it, within the range that was stated.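

In this assay, tert-butyl in place of isobutyl on an oxygen next to a carbonyl group gives a number 22 percentage points higher from compound 3 to compound 4 (beyond the scatter), and this step repeats what the same change did on the core of compound 1: the same change on two cores in this assay, a number 22 percentage points higher (beyond the scatter) from compound 1 to compound 2 and a number 22 percentage points higher (beyond the scatter) from compound 3 to compound 4, 0 percentage points apart, within the scatter of two such steps

The other change, thiophen-2-yl in place of furan-2-yl on a saturated ring carbon, gives a number 2 percentage points lower from compound 2 to compound 4 (within the scatter), and it also repeats across the two cores: the same change on two cores in this assay, a number 2 percentage points lower (within the scatter) from compound 1 to compound 3 and a number 2 percentage points lower (within the scatter) from compound 2 to compound 4, 0 percentage points apart, within the scatter of two such steps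

Together, these four compounds show that each change behaved the same way whichever form the other position took, but this rests on just two cores and two pairs of groups, so it does not show that the changes would carry over to a more different core, and a reading at one concentration says how much inhibition was seen there, not how potent a compound is.

As far as these compounds go, what stays open is whether a longer chain such as n-hexyl, or a cyclohexyl group, on that oxygen would give a larger or smaller number than tert-butyl does. From the compounds shown here alone, it is also open whether a phenyl ring or a pyridine ring on the saturated ring carbon would separate from furan-2-yl and thiophen-2-yl, which show no difference here beyond the usual scatter.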